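Ethoxy to propoxy: the step to compound 4

This account rests on a few compounds, and the source may have more. Where it says the series, first, only, none or still open, it means among the compounds named here.

For the measured compounds named here, in a functional assay on A549 cells (Homo sapiens) for antiproliferative activity, read by MTT assay, with a stated time of 48 h (a higher number here means a weaker inhibitor of growth, a lower number a stronger inhibitor of growth), compound 3 (`CCOC(=O)N1N=C(c2cccc(O)c2)CC1c1cc(OC)c(OC)c(OC)c1`) gives 5120 nM as the only number so far. Compound 1 (`CCCOC(=O)N1N=C(c2ccccc2)CC1c1cc(OC)c(OC)c(OC)c1`), a propoxy compound without the hydroxy group, gives > 10000 nM as a limit. Compound 2 (`CCCOC(=O)N1N=C(c2ccc(OC)cc2)CC1c1cc(OC)c(OC)c(OC)c1`), also propoxy without the hydroxy group, gives > 10000 nM as a limit. Going by the values given here, the only measured step is a step that the two limits leave unreadable from compound 1 to compound 2 and offers no size to carry over. Compound 4 (`CCCOC(=O)N1N=C(c2cccc(O)c2)CC1c1cc(OC)c(OC)c(OC)c1`) departs from compound 3 by methyl in place of hydrogen on a saturated chain carbon, two bonds along the chain from an oxygen next to a carbonyl group (ethoxy to propoxy). Among the compounds with values here, with propoxy in both limit compounds, the limit of > 10000 nM in this assay, at which 2 of the 3 values shown sit, is the only guide to direction. The estimated step, a 1.4-fold higher number from compound 3 to compound 4 (0.14 log units; within the scatter), is expected to be a slight weakening in this assay and may stay within the scatter. Compound 4 is expected at 7000 nM (range 3000 nM to 16000 nM).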

Compound 4, concentration for 50% growth inhibition: > 10000 nM
Compound 4: a limit, no number; the forecaster's own chance of this, stated with the estimate: 35%; at least 1.4-fold (0.15 log units) between middle value and limit.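

In this assay, ethoxy to propoxy gives an at least 1.9-fold higher number from compound 3 to compound 4 (0.29 log units; that floor lies within the scatter), so this position tolerates the added methyl poorly at best only if the true step exceeds that floor. Compound 4 gives > 10000 nM, which is a limit and not a number. All the propoxy compounds now sit at that limit, and the steps among them cannot be read, so no effect of hydroxy on a propoxy compound can be sized: the limit of > 10000 nM in this assay, at which 3 of the 4 values shown sit.

Still open, from the compounds shown here alone, is whether a shorter chain than ethoxy or an amine at the chain end would give a lower number than compound 3.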